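A few compounds are considered here, and "the series" means these few. Any claim that something is new, unique, unknown or untested is made for them only; others in the source may bear on it.

Three members of the series have numbers in a functional assay on PC-12 cells (Rattus norvegicus) for cytotoxicity, read by MTT assay, with stated times of 2 h and 24 h, tested at 1 uM; on this read-out lower numbers stand for a weaker effect and higher numbers for a stronger effect at the one concentration tested. Compound 1 `CCc1ccc(-n2nc(-c3ccc(C(F)(F)F)cc3O)nc2-c2ccccc2O)cc1` gives 64.4%, compound 2 `CC(C)c1ccc(-n2nc(-c3ccc(C(F)(F)F)cc3O)nc2-c2ccccc2O)cc1` gives 69.7%, and compound 3 `CC(C)(C)c1ccc(-n2nc(-c3ccc(C(F)(F)F)cc3O)nc2-c2ccccc2O)cc1` gives 67.3%. The three values sit close together: a number 5.3 percentage points higher from compound 1 to compound 2 (within the scatter), a number 2.9 percentage points higher from compound 1 to compound 3 (within the scatter) and a number 2.4 percentage points lower from compound 2 to compound 3 (within the scatter). Compound 3 thus stands second highest of the three numbers, with compound 2 nearest and compound 1 furthest, but as each gap is within the scatter no order among the three can be read from these values.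

Compound 4 `Oc1cc(C(F)(F)F)ccc1-c1nc(-c2ccccc2O)n(-c2ccc(Br)cc2)n1` is not yet measured. Against compound 3 it differs by bromo in place of tert-butyl on an aromatic carbon, that is 4-(tert-butyl)phenyl to 4-bromophenyl. Within the data shown here, none of the measured steps puts bromo in place of ethyl, isopropyl or tert-butyl; the three steps cover only those three groups on this aromatic carbon, and every one of them stayed within the scatter. Among the measured compounds shown here, no measured step therefore bears directly on the change to compound 4, and the only guidance is that varying the group on this aromatic carbon has so far not moved the read-out in this assay beyond the scatter. On this basis a step of no more than the scatter is expected, in no particular direction, a number 1.3 percentage points lower from compound 3 to compound 4 (within the scatter). For the measured compounds named here, compound 4 is estimated at 66%, with a range from 50% to 82%; the range is set wide since the bromo group has no measured precedent.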

Compound 4, a percentage reported as activity, at one concentration (the size of the read-out at that concentration, not a potency): 69.4%
Estimate against measurement, compound 4: 3.4 percentage points below; the measured number falls inside the stated range.
By their numbers in this assay, from the lowest: compounds 1, 3, 4 and 2 (each within the scatter of the next).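

In this assay the change to bromo stays within the scatter whichever alkyl group it replaces: a number 2.1 percentage points higher from compound 3 to compound 4 (within the scatter) and a number 0.3 percentage points lower from compound 2 to compound 4 (within the scatter) and a number 5 percentage points higher from compound 1 to compound 4 (within the scatter). Among these compounds, this is the first step at this aromatic carbon that replaces carbon substituents with a halogen, and tert-butyl with 4 heavy atoms gives way to bromo with 1 heavy atom, so the flat picture seen among ethyl, isopropyl and tert-butyl now extends to a group of a different element and a much lower heavy-atom count. All four compounds lie within the scatter of one another, no order can be drawn among them, and nothing at hand gives a reason for this flat picture.

Still open, from the compounds shown here alone, is whether an amine or a carboxylic acid on this same aromatic carbon would carry the read-out beyond the scatter, or whether it would stay level with these four compounds. Also open, going by these compounds, is whether replacing the trifluoromethyl group or either hydroxyl group elsewhere on the shared core would shift the read-out, and whether the level picture at a single concentration would hold across a range of concentrations.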